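Hexyloxy for methyl on the sulfonamide aryl ring

This account rests on a few compounds, and the source may have more. Where it says the series, first, only, none or still open, it means among the compounds named here.

Measured compounds:
compound 1 `CCc1ccccc1NS(=O)(=O)c1ccc(N2CCNC2=O)cc1` 240 nM
compound 2 `Cc1ccc(NS(=O)(=O)c2ccc(N3CCNC3=O)cc2)cc1` 480 nM
compound 3 `O=C1NCCN1c1ccc(S(=O)(=O)Nc2cccc(Br)c2)cc1` 77 nM

In a functional assay on HT-29 cells (Homo sapiens) for antiproliferative activity, read by sulforhodamine B assay, with a stated time of 48 h (a lower number here means a stronger inhibitor, a higher number a weaker inhibitor), compound 2 gives the highest of the three numbers; compound 1 lies a 2.0-fold higher number from compound 1 to compound 2 (0.30 log units; within the scatter) away, within the scatter, while compound 3 sits beyond it at a 6.2-fold lower number from compound 2 to compound 3 (0.79 log units; beyond the scatter). Compound 4 `CCCCCCOc1ccc(NS(=O)(=O)c2ccc(N3CCNC3=O)cc2)cc1` differs from compound 2 by hexyloxy in place of methyl on an aromatic carbon. For the measured compounds named here, none of the measured steps changes a group in this way: a 3.1-fold lower number from compound 1 to compound 3 (0.49 log units; beyond the scatter) and a 6.2-fold lower number from compound 2 to compound 3 (0.79 log units; beyond the scatter) both bring in 3-bromophenyl, and a 2.0-fold higher number from compound 1 to compound 2 (0.30 log units; within the scatter) swaps 2-ethylphenyl for 4-methylphenyl without leaving the scatter. Going by the values given here, with no step that exchanges the methyl itself, no change beyond the scatter is expected, so compound 4 is estimated at 400 nM (range 150 nM to 1200 nM), a step of a 1.2-fold lower number from compound 2 to compound 4 (0.08 log units; within the scatter).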

Compound 4, half-maximal inhibitory concentration: > 1000 nM
Compound 4 ended at the assay's limit; the forecaster's own chance of this, stated with the estimate: 5%; middle value at least 2.5-fold (0.39 log units) from the limit.
By their numbers in this assay, from the lowest: compound 3; then compounds 1 and 2 (each within the scatter of the next). At a limit, above all of these: compound 4.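

Hexyloxy in place of methyl on this aromatic carbon, para to a large group, gives an at least 2.0-fold higher number from compound 2 to compound 4 (0.31 log units; beyond the scatter). For the compounds shown here, the earlier steps exchanged whole aryl groups on the sulfonamide nitrogen, so this is the only step confined to this carbon, and it shows that the substituent here can move the number beyond the scatter. In this assay, the reading for compound 4 is a limit of the assay and not a number: the limit of > 1000 nM in this assay, at which 1 of the 4 values shown sits.

Going by these compounds, how far compound 4 truly lies from compound 2 remains open. So does whether a shorter chain such as methoxy or ethoxy, or an amine, on this carbon would keep the number near that of compound 2.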